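The source may report more compounds than this note shows. Statements on the series, on what has been measured and on what is new or still open speak of the compounds shown alone.

Of the compounds shown here, three on a shared core have been tested in a toxicity assay on MT4 cells (Homo sapiens) for cytotoxicity, read by MTT assay; on this read-out lower numbers stand for higher toxicity in this test and higher numbers for lower toxicity in this test: compound 1 (`Cc1cc(-c2ccc(Cl)cc2)cc(C)c1Oc1cc(N)nc(Nc2ccc(C#N)cc2)n1`) gives 21500 nM, compound 2 (`COc1ccc(-c2cc(C)c(Oc3cc(N)nc(Nc4ccc(C#N)cc4)n3)c(C)c2)cc1`) gives 10700 nM, and compound 3 (`Cc1cc(-c2ccc(C#N)cc2)cc(C)c1Oc1cc(N)nc(Nc2ccc(C#N)cc2)n1`) gives 18100 nM. Compound 3 lies within the scatter of both others, so the three cannot be ranked. Compound 4 (`Cc1cc(-c2ccc(C#N)cc2)ccc1Oc1cc(N)nc(Nc2ccc(C#N)cc2)n1`) differs from compound 3 in one place, with hydrogen in place of methyl on an aromatic carbon. The measured steps exchange chloro, methoxy and cyano, and they are small: a 2.0-fold lower number from compound 1 to compound 2 (0.30 log units; within the scatter), a 1.2-fold lower number from compound 1 to compound 3 (0.07 log units; within the scatter) and a 1.7-fold higher number from compound 2 to compound 3 (0.23 log units; within the scatter), all within the scatter. Among the measured compounds shown here, none of them removes a methyl, so the data hold no direct precedent for this change. With only these steps among compound 1, compound 2 and compound 3 as a guide, the expected change in this assay is a 1.1-fold lower number from compound 3 to compound 4 (0.05 log units; within the scatter), not beyond the scatter and in no firm direction. Compound 4 is estimated at 16000 nM, with an expected range from 6500 nM to 38000 nM.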

Compound 4, half-maximal cytotoxic concentration: 10400 nM
For compound 4 the middle estimate is 1.5-fold (0.19 log units) above the measured one; the range from low to high includes it.
By their numbers in this assay, from the lowest: compounds 4, 2, 3 and 1 (each within the scatter of the next, the first and the last beyond it).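

Hydrogen in place of methyl on this aromatic carbon, ortho to a large group and meta to a 4-cyanophenyl group, gives a 1.7-fold lower number from compound 3 to compound 4 (0.24 log units; within the scatter) in this assay and so offers the first direct reading at this position. Within this pair, the read-out does not separate the compound carrying the methyl group from the one carrying hydrogen, so this change shows no firm effect here, just as the exchanges of chloro, methoxy and cyano showed none. The information shown offers nothing that bears on this result.

From the compounds shown here alone, whether an ethyl group or an amine on this carbon would carry the number beyond the scatter stays open, as does the effect of also replacing the remaining methyl group with hydrogen. This step was read with the 4-cyanophenyl group in place, so it leaves open whether the same change would give a similar step in the chloro and methoxy series of compound 1 and compound 2.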